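The source may report more compounds than this note shows. Statements on the series, on what has been measured and on what is new or still open speak of the compounds shown alone.

In a functional assay on A549 cells (Homo sapiens) for antiproliferative activity, read by MTT assay, with a stated time of 72 h (a higher number here means a weaker inhibitor, a lower number a stronger inhibitor), compound 1 `COc1ccc(N2CCN(C(=S)SCc3ccc4nc(N)nc(N)c4c3)CC2)cc1` gives 1590 nM, while compound 2 `Nc1nc(N)c2cc(CSC(=S)N3CCN(c4ccccc4Cl)CC3)ccc2n1` gives 3610 nM, the highest of the two numbers at hand. Among the compounds with values here, the single measured step, a 2.3-fold higher number from compound 1 to compound 2 (0.36 log units; beyond the scatter), comes from exchanging the aryl group on an amine nitrogen in a ring, 2-chlorophenyl in place of 4-methoxyphenyl. Compound 3 `Nc1nc(N)c2cc(CSC(=S)N3CCN(c4ccc(F)cc4F)CC3)ccc2n1` alters that same aryl group once more: 2,4-difluorophenyl in place of 2-chlorophenyl on an amine nitrogen in a ring. Because a 2.3-fold higher number from compound 1 to compound 2 (0.36 log units; beyond the scatter) was modest and involved a different pair of aryl groups, it offers only a rough guide to the size of the present step and no guide to its direction. For compound 3 the expected step is therefore small, a 1.4-fold lower number from compound 2 to compound 3 (0.16 log units; within the scatter), with either direction considered possible. Compound 3 is accordingly estimated at 2500 nM in this assay, within a range from 1100 nM to 6000 nM.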

Compound 3, half-maximal inhibitory concentration: 5120 nM
The estimate for compound 3 lay 2.0-fold (0.31 log units) below the measured number; the range from low to high includes it.
By their numbers in this assay, from the lowest: compound 1; then compounds 2 and 3 (each within the scatter of the next).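

In this assay, putting 2,4-difluorophenyl in place of 2-chlorophenyl on the amine nitrogen in the ring gives a 1.4-fold higher number from compound 2 to compound 3 (0.15 log units; within the scatter), so these two halogen-bearing aryl groups cannot be told apart at this position. Putting 2,4-difluorophenyl in place of 4-methoxyphenyl at the same position gives a 3.2-fold higher number from compound 1 to compound 3 (0.51 log units; beyond the scatter), which leaves compound 1, with its 4-methoxyphenyl group, with the lowest number of the three and shows that this gap is not confined to the 2-chlorophenyl group. Nothing available here accounts for that gap.

From the compounds shown here alone, all three compounds carry a substituted phenyl on that nitrogen, so how a plain phenyl, a benzyl group or an acetyl group there would compare remains open. Going by these compounds, it is also open whether the lower number of compound 1 goes with the methoxy group itself.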